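The source may report more compounds than this note shows. Statements on the series, on what has been measured and on what is new or still open speak of the compounds shown alone.

Compound 1 `Cc1cc(=O)n(-c2cccc(F)c2)nc1C(=O)Nc1ccc(Oc2ncnc3[nH]ccc23)c(F)c1`: in a functional assay on MCF7 cells (Homo sapiens) for cytotoxicity, read by MTT assay, with a stated time of 72 h (a higher number here means a weaker inhibitor, a lower number a stronger inhibitor), compound 1 gives 32000 nM.
Compound 2 `Cc1cc(=O)n(-c2ccccc2OC(F)(F)F)nc1C(=O)Nc1ccc(Oc2ncnc3c2ccn3C)c(F)c1`: in this assay compound 2 gives no number but a limit of the assay, > 60000 nM.

Compound 2 therefore stands at the edge of what this assay reports, where (the limit of > 60000 nM in this assay, at which 1 of the 2 values shown sits). The step to compound 3 `Cc1cc(=O)n(-c2cccc(F)c2)nc1C(=O)Nc1ccc(Oc2ncnc3c2ccn3C)c(F)c1` exchanges (3-fluorophenyl in place of 2-(trifluoromethoxy)phenyl on an aromatic nitrogen). Among the compounds with values here, no measured pair differs in only this one place, so the size of this step cannot be read from the values shown. Compound 1, which carries the same 3-fluorophenyl, gives 32000 nM in this assay. Compound 3 is therefore expected to remain weak, near 50000 nM, within a range from 20000 nM to 150000 nM. That estimate means a step of about an at least 1.2-fold lower number from compound 2 to compound 3 (0.07 log units; that floor lies within the scatter), no clearer than the scatter.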

Compound 3, half-maximal inhibitory concentration: > 60000 nM
Compound 3: a limit, no number (the forecaster's own chance of this, stated with the estimate: 45%); middle value at least 1.2-fold (0.07 log units) away from the limit.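

In this assay compound 3 gives only a limit, > 60000 nM and no number, so 3-fluorophenyl on this nitrogen, with the methyl kept on the other aromatic nitrogen, brings no readable value. Methyl in place of hydrogen on that other nitrogen gives an at least 1.8-fold higher number from compound 1 to compound 3 (0.27 log units; that floor lies within the scatter) and no clearer change can be claimed. The exchange of the two aryl groups cannot be sized, because both compounds end at a limit: the limit of > 60000 nM in this assay, at which 2 of the 3 values shown sit.

Going by these compounds, whether a longer chain such as butyl, or an amine-bearing chain, on this nitrogen would give a readable number stays open.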